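Chloro to Methoxy: What to Expect for Compound 3

The source may hold more compounds than are shown below. What is called first, only, known or untested is meant among the compounds shown, and "the series" means these compounds.

Compound 1, `FC(F)(F)c1ccc(CSc2nc(N3CCCCC3)c3ccccc3n2)cc1`: in a functional assay on MCF7 cells (Homo sapiens) for cytotoxicity, read by MTT assay, with a stated time of 72 h (on this read-out lower numbers stand for stronger inhibition and higher numbers for weaker inhibition), compound 1 gives > 50000 nM, which is a limit of the assay rather than a number.
Compound 2, `FC(F)(F)c1ccc(CSc2nc(Nc3ccc(Cl)cc3)c3ccccc3n2)cc1`: in this assay compound 2 gives 21500 nM.

Going by the values given here, compound 2 therefore holds the only actual number in this assay; the one other value is a limit, as recorded in the limit of > 50000 nM in this assay, at which 1 of the 2 values shown sits. Among the compounds with values here, the single measured step, an at least 2.3-fold lower number from compound 1 to compound 2 (0.36 log units; beyond the scatter), concerns the exchange of the whole piperidin-1-yl group for (4-chlorophenyl)amino.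

Compound 3, `COc1ccc(Nc2nc(SCc3ccc(C(F)(F)F)cc3)nc3ccccc23)cc1`, is not yet measured. It differs from compound 2 by methoxy in place of chloro on an aromatic carbon, that is, at the place para to a large group on the (4-chlorophenyl)amino ring. Within the data shown here, no measured step touches this position, so the data give no direction for it. Compound 3 is expected to come out near compound 2, and the step of a 1.2-fold higher number from compound 2 to compound 3 (0.07 log units; within the scatter) is expected to stay within the scatter. For compound 3 the estimate in this assay is 25000 nM, with a range from 8000 nM to 60000 nM.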

Compound 3, half-maximal inhibitory concentration: 47200 nM
Estimate against measurement, compound 3: 1.9-fold (0.28 log units) below; the measured number falls inside the stated range.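

Methoxy in place of chloro on the aromatic carbon para to a large group gives a 2.2-fold higher number from compound 2 to compound 3 (0.34 log units; beyond the scatter) in this assay, so this place, which no earlier step touched, does respond to a change, and here the change leads towards weaker inhibition. The step gained with (4-chlorophenyl)amino in place of piperidin-1-yl is not shown to hold for the methoxy partner, since (4-methoxyphenyl)amino in place of piperidin-1-yl gives an at least 1.0-fold lower number from compound 1 to compound 3 (0.02 log units; that floor lies within the scatter), and that floor does not separate the two compounds. Compound 1 remains a limit of the assay and not a number, which is why the true size of that step stays unknown: the limit of > 50000 nM in this assay, at which 1 of the 3 values shown sits.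

With only chloro and methoxy at this place, the compounds shown leave open whether the step reflects something general or just this pair, and a fluoro, a methyl, a hydroxy or an amine on the same carbon could settle that. They also leave open whether the same exchange would give a similar step with a nitrile in place of the trifluoromethyl on the other side of the molecule.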